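Amino to iodo in an antiproliferative compound

The source may report more compounds than this note shows. Statements on the series, on what has been measured and on what is new or still open speak of the compounds shown alone.

In a functional assay on U-937 cells (Homo sapiens) for antiproliferative activity, with a stated time of 48 h (on this read-out lower numbers stand for an effect already at smaller amounts and higher numbers for an effect only at larger amounts of compound), compound 1 (`Nc1ccc(NC(=O)CCCCCCC(=O)NO)cc1`) gives 6400 nM. In the same this assay, compound 2 (`O=C(CCCCCCC(=O)Nc1ccccc1Br)NO`) gives 6800 nM. These two numbers lie within the usual scatter of each other, so compound 1 stands level with compound 2 and the two cannot be ranked. Among the compounds with values here, no measured step in a single place links them, and the data therefore offer no direct guide to what one substitution does.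

Compound 3 (`O=C(CCCCCCC(=O)Nc1ccc(I)cc1)NO`) has not yet been measured. It departs from compound 1 in one place: iodo in place of amino on an aromatic carbon. This puts iodo in place of amino on an aromatic carbon, para to a large group.

Within the data shown here, the only measured values, compound 1 at 6400 nM and compound 2 at 6800 nM, sit close together and point in no direction. No step beyond the scatter is therefore expected in this assay, neither upward nor downward. The estimated change is a 1.3-fold lower number from compound 1 to compound 3 (0.11 log units; within the scatter). For compound 3 the expected value is 5000 nM, with an estimated range from 2000 nM to 12000 nM.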

Compound 3, half-maximal effective concentration: 120 nM
Compound 3: the middle estimate sits 42-fold (1.62 log units) above what was measured; measured number below the stated range.
By their numbers in this assay, from the lowest: compound 3; then compounds 1 and 2 (each within the scatter of the next).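

The position para to a large group on the aromatic ring is not indifferent in this assay: iodo in place of amino on this aromatic carbon gives a 53-fold lower number from compound 1 to compound 3 (1.73 log units; beyond the scatter), a step well beyond the scatter and the first single-place step available in this set. The change involves only one heavy atom, with one hydrogen-bond donor and one hydrogen-bond acceptor leaving and neither entering, so a substitution this small at this place is enough to separate compound 3 clearly from compound 1. Nothing measured here bears on what lies behind the size of this step.

The compounds shown leave open whether the step belongs to the arrival of iodo or to the departure of amino, a question that a plain hydrogen, chloro or methyl at the same place would help to settle. They also leave open whether iodo would give a step of similar size on a longer or shorter chain, and compound 2 cannot answer this or the position question, as it differs from compound 3 in more than one place.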